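From 4-hydroxyphenyl to 3-fluorophenyl on the shared core

The source may report more compounds than this note shows. Statements on the series, on what has been measured and on what is new or still open speak of the compounds shown alone.

In an ADME assay on HepG2 cells (Homo sapiens) for cytotoxicity, read by MTT assay, with a stated time of 72 h (on this read-out higher numbers stand for lower toxicity in this test and lower numbers for higher toxicity in this test), compound 2 (`O=[N+]([O-])c1c(CS(=O)(=O)c2ccccc2)nc2c(-c3ccc(O)cc3)cc(Cl)cn12`) gives > 12500 nM as a limit and not a number. Compound 1 (`O=Cc1ccc(-c2cc(Cl)cn3c([N+](=O)[O-])c(CS(=O)(=O)c4ccccc4)nc23)cc1`) gives > 31200 nM as a limit as well. Compound 2 therefore has no exact position on this read-out.

Compound 3 (`O=[N+]([O-])c1c(CS(=O)(=O)c2ccccc2)nc2c(-c3cccc(F)c3)cc(Cl)cn12`) carries 3-fluorophenyl in place of 4-hydroxyphenyl on an aromatic carbon of the shared core (3-fluorophenyl in place of 4-hydroxyphenyl on an aromatic carbon). Within the data shown here, the only measured step is a step that the two limits leave unreadable from compound 1 to compound 2 and concerns a different change. It offers no size or direction to carry over, so no step beyond the scatter is expected in this assay for this change. The estimated step is a step that the limit leaves unreadable from compound 2 to compound 3 and remains an expectation only. For compound 3 the estimated half-maximal cytotoxic concentration is 20000 nM with an expected range from 7000 nM to 50000 nM and a good chance that the outcome is expected to be only a limit.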

Compound 3, half-maximal cytotoxic concentration: > 12500 nM
Compound 3: only a limit was reported; the forecaster's own chance of this, stated with the estimate: 60%; the middle value lies beyond the limit too.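

In this assay, among these compounds, compound 1, compound 2 and compound 3 all give limits only, and no step among them can be read. Still open, as far as these compounds go, is the exact half-maximal cytotoxic concentration of each compound, and so how 3-fluorophenyl compares with 4-hydroxyphenyl on the shared core.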